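Removing a Ring Methyl: Cytotoxicity in Human Fibroblasts

A few compounds are considered here, and "the series" means these few. Any claim that something is new, unique, unknown or untested is made for them only; others in the source may bear on it.

Measured compounds:
compound 1, `O=[N+]([O-])c1cn2c(n1)OC(COc1ccc(-c3ccc(F)nc3F)nc1)CC2`, > 64000 nM
compound 2, `CC1(COc2ccc(-c3ccc(F)nc3F)nc2)CCn2cc([N+](=O)[O-])nc2O1`, > 64000 nM
compound 3, `CC1(COc2ncc(-c3ccc(F)cc3)cn2)CCn2cc([N+](=O)[O-])nc2O1`, 57000 nM

In an ADME assay on MRC5 cells (Homo sapiens) for cytotoxicity, read by resazurin assay, with a stated time of 72 h (on this read-out lower numbers stand for stronger inhibition and higher numbers for weaker inhibition), compound 1 reaches only the limit of the assay and gives > 64000 nM. Compound 2 likewise gives a limit, > 64000 nM, in this assay. Within the data shown here, compound 3 is the one compound with an actual number here: in this assay compound 3 gives 57000 nM. The difference between the core of compound 3 and the core of compound 2 is not broken down here.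

Compound 1 and compound 2 differ by one change, (hydrogen in place of methyl on a saturated ring carbon). The step that the two limits leave unreadable from compound 2 to compound 1 cannot be read, since both values sit at the limit (the limit of > 64000 nM in this assay, at which 2 of the 3 values shown sit).

Compound 4, `O=[N+]([O-])c1cn2c(n1)OC(COc1ncc(-c3ccc(F)cc3)cn1)CC2`, is not yet measured. It differs from compound 3 by hydrogen in place of methyl on a saturated ring carbon, the same change as from compound 2 to compound 1, with the same place word for word. Since that earlier step is unreadable, the expectation for compound 4 rests on the value of compound 3, 57000 nM, which lies close to the top of the assay. The results for compound 1 and compound 2 are each only a limit of the assay. Compound 4 is therefore expected to give 60000 nM in this assay, between 28000 nM and 128000 nM, which means an expected step of a 1.1-fold higher number from compound 3 to compound 4 (0.02 log units; within the scatter). It is estimated that the result for compound 4 may well again be only a limit.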

Compound 4, half-maximal inhibitory concentration: > 64000 nM
Compound 4 ended at the assay's limit; the forecaster's own chance of this, stated with the estimate: 50%; middle value at least 1.0-fold (0.02 log units) from the limit.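

In this assay, hydrogen in place of methyl on a saturated ring carbon, next to the ring oxygen, comes out as an at least 1.1-fold higher number from compound 3 to compound 4 (0.05 log units; that floor lies within the scatter). From the compounds shown here alone, on the core of compound 3, then, the change gives no sign of a lower number, but the result for compound 4 is only a limit, so the true size of the step stays unknown and what can be read of it does not rise clear of the scatter. The same change on the other core cannot be read at all, which leaves no two sizes to set side by side, so the series shows only that the change fits both cores without any visible drop in the number, not that it acts to the same extent on each: the limit of > 64000 nM in this assay, at which 3 of the 4 values shown sit.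

The compounds shown leave open what a group other than hydrogen would do on that ring carbon, such as an ethyl group, a longer chain or an amine. They also leave open whether the change could be sized on a compound whose value lies well clear of the limit, for instance one carrying a carboxylic acid in place of a fluorine.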